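From ethyl to 3-chlorophenyl on an amide-type nitrogen

The source may report more compounds than this note shows. Statements on the series, on what has been measured and on what is new or still open speak of the compounds shown alone.

Compound 1 (`CC1(C)CC(NC(=O)Nc2cccc(Cl)c2)c2cc(Br)ccc2O1`): 69000 nM
Compound 2 (`CC(=O)NC1CC(C)(C)Oc2ccc(Cl)cc21`): > 100000 nM as a limit
Compound 3 (`CCNC(=O)NC1CC(C)(C)Oc2ccc(Cl)cc21`): > 100000 nM as a limit
Compound 4 (`CC1(C)CC(NC(=O)Nc2cccc(Cl)c2)c2cc(Cl)ccc2O1`): not yet measured

All of these readings come from a functional assay on U-373MG ATCC cells (Homo sapiens) for inhibition, read by MTT assay, with a stated time of 72 h (a higher number here means a weaker inhibitor, a lower number a stronger inhibitor), and give the half-maximal inhibitory concentration. Compound 3 has no number, only the limit > 100000 nM as its reading. Going by the values given here, compound 2 and compound 3 stand at the limit of > 100000 nM in this assay, at which 2 of the 3 values shown sit, and compound 1 is the only one with a number.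

The change to compound 4 is 3-chlorophenyl in place of ethyl on an amide-type nitrogen, which also reads as ethylamino to (3-chlorophenyl)amino. Among the compounds with values here, the only measured step is a step that the two limits leave unreadable from compound 2 to compound 3 and it offers no size to carry over. The nearest guide is compound 1, which carries the same (3-chlorophenyl)amino group and gives 69000 nM as a true number, although its core is not that of compound 4. Within the data shown here, no measured step covers that difference in the core.

In this assay a move towards a stronger inhibitor is therefore expected, and the estimated size is an at least 1.6-fold lower number from compound 3 to compound 4 (0.22 log units; that floor lies within the scatter) with some uncertainty. Compound 4 is estimated at 60000 nM with an expected range from 30000 nM to 100000 nM and the reading may still turn out to be only a limit.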

Compound 4, half-maximal inhibitory concentration: 21000 nM
Estimate against measurement, compound 4: 2.9-fold (0.46 log units) above; the whole stated range lies above it.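

In this assay, the change on the amide-type nitrogen gives this position its first readable size, an at least 4.7-fold lower number from compound 3 to compound 4 (0.67 log units; beyond the scatter), whereas the earlier step between the two limits could not be read. The step that replaces the methyl on the carbonyl carbon points the same way, an at least 4.7-fold lower number from compound 2 to compound 4 (0.67 log units; beyond the scatter), and the two compounds with the (3-chlorophenyl)amino group give true numbers while the other two do not: the limit of > 100000 nM in this assay, at which 2 of the 4 values shown sit. With that group held fixed, chloro in place of bromo on an aromatic carbon also matters, a 3.3-fold lower number from compound 1 to compound 4 (0.52 log units; beyond the scatter), so the group on the aromatic carbon moves the reading as well as the group on the nitrogen.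

From the compounds shown here alone, whether the gain on the nitrogen follows the aromatic ring or its chlorine stays open, and a plain phenyl or a cyclohexyl there would separate the two. Also open, going by these compounds, are the full size of the two steps that start from a limit, and whether fluoro or methyl on that aromatic carbon would continue the move seen from bromo to chloro.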